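The source may report more compounds than this note shows. Statements on the series, on what has been measured and on what is new or still open speak of the compounds shown alone.

Compound 1, `CC1CCN(C2CCN(S(=O)(=O)c3cccc(C(F)(F)F)c3)CC2)CC1`, gives > 5000 nM in a functional assay on DLD-1 cells (Homo sapiens) for antiproliferative activity, read by CellTiter-Glo, with a stated time of 72 h (a lower number here means a stronger inhibitor, a higher number a weaker inhibitor), which is a limit of the assay rather than a number. Compound 2, `CC1CCN(C2CCN(S(=O)(=O)c3ccc(F)cc3F)CC2)CC1`, gives 102 nM in this assay. Compound 3, `CC1CCN(C2CCN(S(=O)(=O)c3ccc(Cl)c(C(F)(F)F)c3)CC2)CC1`, gives 17 nM in this assay.

Compound 1 therefore stands at the weak end of what has been measured, known only through that limit (the limit of > 5000 nM in this assay, at which 1 of the 3 values shown sits). Compound 4, `Cc1ccc(-c2cccc(S(=O)(=O)N3CCC(N4CCC(C)CC4)CC3)c2)cc1`, differs from it by 4-methylphenyl in place of trifluoromethyl on an aromatic carbon. Among the measured compounds shown here, the only measured step starting from compound 1 is an at least 290-fold lower number from compound 1 to compound 3 (2.46 log units; beyond the scatter), a large gain; it adds chloro rather than exchanging the trifluoromethyl, so it bears on compound 4 only loosely, showing that changes on this ring can turn the shared core into a strong inhibitor. A gain with wide uncertainty is expected, namely an at least 3.3-fold lower number from compound 1 to compound 4 (0.52 log units; beyond the scatter). Compound 4 is estimated at 1500 nM in this assay, within 200 nM to 10000 nM.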

Compound 4, half-maximal inhibitory concentration: 11 nM
Estimate against measurement, compound 4: 140-fold (2.13 log units) above; measured number outside the range, below it.
By their numbers in this assay, from the lowest: compounds 4 and 3 (each within the scatter of the next); then compound 2. At a limit, above all of these: compound 1.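

Replacing trifluoromethyl with 4-methylphenyl on this aromatic carbon gives an at least 450-fold lower number from compound 1 to compound 4 (2.65 log units; beyond the scatter), so the position takes a much larger group carrying a second aromatic ring, and the shared core reaches strong inhibition with the trifluoromethyl gone. Among the compounds shown here, the only earlier gain from compound 1 came from adding chloro while trifluoromethyl stayed in place. The true size of this step remains unknown because compound 1 is known only through a limit: the limit of > 5000 nM in this assay, at which 1 of the 4 values shown sits.

Still open, from the compounds shown here alone, is whether the methyl on the new ring contributes to the gain, or the ring alone accounts for it. Also open, going by these compounds, is how an amine or a carboxylic acid on that ring would compare.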